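The source may hold more compounds than are shown below. What is called first, only, known or untested is meant among the compounds shown, and "the series" means these compounds.

Measured compounds in an assay on isolated protein for binding affinity to leukotriene B4 receptor 1 (Homo sapiens), tested at 1 uM; on this read-out higher numbers stand for more inhibition at the one concentration tested (going by the name of the read-out) and lower numbers for less inhibition:
- compound 1 `C=CCc1cc(C(C)=O)c(O)cc1OCCCCCC#N` gives 41%
- compound 2 `CCc1cc(C(C)=O)c(O)cc1OCCCC(C)(C)c1nnn[nH]1` gives 76%
- compound 3 `CCc1cc(C(C)=O)c(O)cc1OCCCCCCC(C)(C)c1nnn[nH]1` gives 67%

Compound 1 stands lowest of the three numbers in this assay. Its nearest neighbour is compound 3, which lies higher by a margin beyond the scatter; compound 2 lies furthest, higher again by a margin beyond the scatter. Going by the values given here, no pair among the three differs in one place only, so the gaps give no single structural reading; compound 2 and compound 3 share a tetrazole-terminated chain that compound 1 lacks, and compound 1 alone carries the allyl group, so these differences are confounded.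

Compound 4 `C=CCc1cc(C(C)=O)c(O)cc1OCCCCCC(C)=O` is not yet measured in this assay. It differs from compound 1 as follows: acetyl in place of cyano on a saturated chain carbon, five bonds along the chain from an oxygen on an aromatic ring. One neutral group with one hydrogen-bond acceptor is exchanged for another of the same kind on the same chain position. Among the compounds with values here, nothing among the measured compounds isolates this exchange, so the expectation rests on the closeness of the two groups alone: a step of no more than the usual scatter is expected, with a slight upward lean, a number 4 percentage points higher from compound 1 to compound 4 (within the scatter). Compound 4 is thus estimated at 45%, with a range from 25% to 65%.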

Compound 4, a percentage reported as inhibition, at one concentration (the size of the read-out at that concentration, not a potency): 58%
Compound 4: the middle estimate sits 13 percentage points below what was measured, within the range that was stated.
By their numbers in this assay, from the lowest: compound 1; then compounds 4, 3 and 2 (each within the scatter of the next, the first and the last beyond it).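

In this assay, going by these compounds alone, the acetyl for cyano exchange, on a saturated chain carbon, five bonds along the chain from an oxygen on an aromatic ring, gives a number 17 percentage points higher from compound 1 to compound 4 (beyond the scatter), and this is the first comparison that differs in one place only. It shows that this position responds to the group it carries, even though both groups count no hydrogen-bond donors, one hydrogen-bond acceptor and no net charge. The counted differences are a triple bond and two heavy atoms for cyano against a double bond and three heavy atoms for acetyl; nothing shown separates these, and no measurement at hand bears on why the step arises.

Open, on these data alone, is whether a carboxylic acid or a primary amide at the same place would move the number further than acetyl does, and whether a shorter or longer chain keeps the step. Also open, as far as these compounds go, is whether the step carries over when ethyl, as in compound 2 and compound 3, stands in place of the allyl group of compound 1 and compound 4.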